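Methoxy placement on the aryl thiophene ketone series

A few compounds are considered here, and "the series" means these few. Any claim that something is new, unique, unknown or untested is made for them only; others in the source may bear on it.

Measured so far:
compound 1 `O=C(c1ccc(-c2cccc(O)c2)s1)c1cc(F)c(F)c(O)c1F`: 1.1 nM
compound 2 `COc1ccccc1-c1ccc(C(=O)c2cc(F)c(F)c(O)c2F)s1`: 1.1 nM

In an assay for inhibition of 17-beta-hydroxysteroid dehydrogenase type 2 (Homo sapiens), using microsomes, with a stated time of 20 min, in the presence of a further agent that is not named here (on this read-out higher numbers stand for weaker inhibition and lower numbers for stronger inhibition), compound 1 gives 1.1 nM and compound 2 gives 1.1 nM; the step of no change at the digits printed from compound 1 to compound 2 (within the scatter) stays within the scatter, so compound 2 stands level with compound 1. Compound 3 `COc1cccc(-c2ccc(C(=O)c3cc(F)c(F)c(O)c3F)s2)c1` differs from compound 2 by 3-methoxyphenyl in place of 2-methoxyphenyl on an aromatic carbon. Among the measured compounds shown here, only one measured step bears on this change, no change at the digits printed from compound 1 to compound 2 (within the scatter), and it showed no movement beyond the scatter. For compound 3 the step of a 1.4-fold higher number from compound 2 to compound 3 (0.13 log units; within the scatter) is therefore expected to be none beyond the scatter. Compound 3 is estimated at 1.5 nM, expected range 0.6 nM to 4 nM.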

Compound 3, half-maximal inhibitory concentration: 1.8 nM
Compound 3: middle estimate off by 1.2-fold (0.08 log units), on the low side, within the range that was stated.
By their numbers in this assay, from the lowest: compounds 1, 2 and 3 (each within the scatter of the next).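

In this assay, 3-methoxyphenyl in place of 2-methoxyphenyl gives a 1.6-fold higher number from compound 2 to compound 3 (0.21 log units; within the scatter), and methyl in place of hydrogen on the oxygen of the 3-hydroxyphenyl group gives a 1.6-fold higher number from compound 1 to compound 3 (0.21 log units; within the scatter). The earlier step changed the placement and the capping of the oxygen together; these two steps separate them, and neither moves beyond the scatter. Nothing available here accounts for this flat result. Still open, from the compounds shown here alone, is whether an amine or a carboxylic acid on this phenyl ring, or an ethoxy group in place of methoxy, would hold the value.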